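A second methyl on the aryl ether of compound 1

A few compounds are considered here, and "the series" means these few. Any claim that something is new, unique, unknown or untested is made for them only; others in the source may bear on it.

Compound 1 `COc1ccc(-c2csc(NC(=O)COc3ccc(C(=O)c4ccccc4)cc3C)n2)cc1` is measured in a functional assay on Ehrlich cells (Mus musculus) for cytotoxicity, read by MTT assay, with a stated time of 48 h (on this read-out higher numbers stand for weaker inhibition and lower numbers for stronger inhibition), where compound 1 gives 28400 nM. Its nearest neighbour is compound 2 `COc1ccc(-c2csc(NC(=O)COc3ccc(C(=O)c4ccc(C)cc4)cc3C)n2)cc1`, which in this assay gives 20700 nM; of the two numbers that of compound 1 is the higher, yet a 1.4-fold lower number from compound 1 to compound 2 (0.14 log units; within the scatter) lies within the scatter. Compound 3 `COc1ccc(-c2csc(NC(=O)COc3c(C)cc(C(=O)c4ccccc4)cc3C)n2)cc1` differs from compound 1 by methyl in place of hydrogen on an aromatic carbon. For the measured compounds named here, the only comparable step, a methyl for a hydrogen on an aromatic carbon, moved nothing beyond the scatter, so a 1.1-fold lower number from compound 1 to compound 3 (0.06 log units; within the scatter) is expected to be no more than scatter. Compound 3 is therefore estimated at 25000 nM, within 10000 nM to 60000 nM.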

Compound 3, half-maximal inhibitory concentration: 41200 nM
Estimate against measurement, compound 3: 1.6-fold (0.22 log units) below; low and high end bracket the measured number.
By their numbers in this assay, from the lowest: compounds 2, 1 and 3 (each within the scatter of the next).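

In this assay a methyl on this aromatic carbon, ortho to a large group and meta to a benzoyl group, gives a 1.5-fold higher number from compound 1 to compound 3 (0.16 log units; within the scatter) and so shows that this position, too, takes the change without a shift beyond the scatter. Together with the earlier step (a 1.4-fold lower number from compound 1 to compound 2 (0.14 log units; within the scatter)), two methyl-for-hydrogen changes in different places now stay within the scatter. Nothing at hand bears on the reason for this result.

From the compounds shown here alone, whether a methoxy group, an amine or a carboxylic acid on this same carbon would move the number beyond the scatter remains open.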